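The source may report more compounds than this note shows. Statements on the series, on what has been measured and on what is new or still open speak of the compounds shown alone.

Measured compounds in a functional assay on CHO-K1 cells for antagonist activity at adenosine receptor A1 (Homo sapiens), read by a beta-galactosidase reporter and cAMP accumulation, with stated times of 15 min and 6 h; a higher number here means a weaker inhibitor, a lower number a stronger inhibitor:
- compound 1, `Cc1ccc(-c2nc(N)c3cc(Cc4ccccc4)sc3n2)o1`: 298 nM
- compound 2, `Nc1nc(-c2ccc(C(F)F)o2)nc2sc(Cc3ccccc3)cc12`: 3000 nM
- compound 3, `N#Cc1cccc(-c2nc(N)c3cc(Cc4ccccc4)sc3n2)c1`: 222 nM

Among these three, compound 3 gives the lowest number in this assay. Compound 1 sits close to it: the step of a 1.3-fold lower number from compound 1 to compound 3 (0.13 log units; within the scatter) is within the scatter, so the two cannot be ranked. Compound 2 is far off, as the step of a 14-fold lower number from compound 2 to compound 3 (1.13 log units; beyond the scatter) shows.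

Compound 4, `N#Cc1cccc(-c2nc(N)c3cc(Cc4ccccc4)sc3n2)n1`, has not yet been measured. It differs from compound 3 in one place: 6-cyanopyridin-2-yl in place of 3-cyanophenyl on an aromatic carbon. Within the data shown here, none of the measured steps tests this kind of exchange. The steps of a 10-fold higher number from compound 1 to compound 2 (1.00 log units; beyond the scatter) and a 1.3-fold lower number from compound 1 to compound 3 (0.13 log units; within the scatter) concern a different group at the same position of the shared core, and they show that a change there can leave the number nearly unchanged or can shift it by a modest amount. For compound 4 the expectation is therefore a step of about a 1.4-fold higher number from compound 3 to compound 4 (0.13 log units; within the scatter), that is, no change clearly beyond the scatter, with a wide range to reflect the lack of a directly comparable step. The estimated value for compound 4 is 300 nM, expected to lie between 90 nM and 1000 nM.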

Compound 4, inhibition constant: > 1000 nM
Compound 4: a limit, no number; the forecaster's own chance of this, stated with the estimate: 3%; middle value at least 3.3-fold (0.52 log units) away from the limit.
By their numbers in this assay, from the lowest: compounds 3 and 1 (each within the scatter of the next); then compound 2.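

In this assay compound 4 carries a limit and not a number: the limit of > 1000 nM in this assay, at which 1 of the 4 values shown sits.
Even so, the step of an at least 4.5-fold higher number from compound 3 to compound 4 (0.65 log units; beyond the scatter) shows that one ring carbon exchanged for a ring nitrogen, with the nitrile kept and the number of heavy atoms the same, is enough to move the number beyond the scatter, a kind of change the earlier compounds did not test. The step of an at least 3.3-fold higher number from compound 1 to compound 4 (0.52 log units; beyond the scatter) shows that 6-cyanopyridin-2-yl also falls behind 5-methylfuran-2-yl, whereas 3-cyanophenyl could not be ranked against that group, and the step to compound 2 cannot be read.

On these data alone, how far compound 4 really lies from the others stays unknown, since the limit gives no number. Also open, as far as these compounds go, is whether the loss belongs to the ring nitrogen alone or to its pairing with the nitrile, which a pyridin-2-yl group carrying an amine or a methyl in place of the nitrile could separate.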